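This account rests on a few compounds, and the source may have more. Where it says the series, first, only, none or still open, it means among the compounds named here.

Measured compounds:
- compound 1 `Clc1cccc(Nc2ncnc3ccc(NCc4ccc5c(c4)OCCCCO5)cc23)c1`: 17.5 ug/mL
- compound 2 `Clc1cccc(Nc2ncnc3ccc(NCc4ccc5c(c4)OCCCO5)cc23)c1`: 2.14 ug/mL
- compound 3 `O=C(Nc1ccc2ncnc(Nc3cccc(Br)c3)c2c1)C1COc2ccccc2O1`: 50.1 ug/mL

In a functional assay on B16-F10 cells (Mus musculus) for antiproliferative activity, read by WST assay, with a stated time of 48 h (on this read-out higher numbers stand for weaker inhibition and lower numbers for stronger inhibition), compound 1 gives 17.5 ug/mL, the second highest of the three numbers. The nearest value is that of compound 3 at 50.1 ug/mL, a higher number beyond the scatter; compound 2 at 2.14 ug/mL stands furthest away, a lower number, also beyond the scatter. Among the measured compounds shown here, no step between two measured compounds differing in one place is available.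

Compound 4 `Brc1cccc(Nc2ncnc3ccc(NCc4ccc5c(c4)OCCCCO5)cc23)c1` has not yet been tested in this assay. It differs from compound 1 by bromo in place of chloro on an aromatic carbon. Lacking any measured pair showing this exchange, the step from compound 1 to compound 4 is expected to be a 1.2-fold lower number from compound 1 to compound 4 (0.07 log units; within the scatter), within the scatter, with no direction preferred. Compound 4 is thus estimated at 15 ug/mL, likely between 6 ug/mL and 40 ug/mL.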

Compound 4, half-maximal inhibitory concentration: 20.6 ug/mL
Estimate against measurement, compound 4: 1.4-fold (0.14 log units) below; measured number inside the range.
By their numbers in this assay, from the lowest: compound 2; then compounds 1 and 4 (each within the scatter of the next); then compound 3.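

In this assay the exchange of chloro for bromo at this place on the aromatic ring gives a 1.2-fold higher number from compound 1 to compound 4 (0.07 log units; within the scatter) and so leaves the read-out unchanged within the scatter. Among the compounds shown here, at this position, with this side chain, the two halogens are therefore not told apart, which no earlier compound could show. Nothing measured here accounts for this result.

Open, going by these compounds, is whether a methyl, a methoxy or a nitrile at the same place would also leave the read-out unchanged. Also open, on these data alone, is whether bromo and chloro stay equal on the side chain of compound 2.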